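From Ethoxy to Methyl on a Carbonyl Carbon

This account rests on a few compounds, and the source may have more. Where it says the series, first, only, none or still open, it means among the compounds named here.

Compound 1 `CCOC(=O)Nc1cccc(C(=O)CSC(=S)SCC)c1`: 2000 nM
Compound 2 `CCSC(=S)SCC(=O)c1ccc(NS(C)(=O)=O)cc1`: 39800 nM

Both values come from a functional assay on HeLa cells (Homo sapiens) for antiproliferative activity, read by resazurin assay; on this read-out higher numbers stand for weaker inhibition and lower numbers for stronger inhibition. Of the two measured compounds, compound 1 holds the lower number, 2000 nM, and so is the stronger inhibitor. Compound 2 reads higher, by a gap beyond the usual scatter.

Going by the values given here, compound 3 `CCSC(=S)SCC(=O)c1cccc(NC(C)=O)c1` has no measurement yet. It departs from compound 1 in one place: methyl in place of ethoxy on a carbonyl carbon. Read one bond further out, (ethoxycarbonyl)amino becomes acetamido, while the rest of the core of compound 1 stays the same.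

Among the compounds with values here, no measured pair shows this change on its own, so the expectation is anchored on compound 1 at 2000 nM, and it remains uncertain. A moderate move towards a higher number is expected in this assay, and it may only just clear the scatter. The estimate amounts to a step of a 2.5-fold higher number from compound 1 to compound 3 (0.40 log units; beyond the scatter), which is an expected and not a measured change. For compound 3 the estimated value is 5000 nM, with an expected range from 1500 nM to 16000 nM.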

Compound 3, half-maximal inhibitory concentration: 10000 nM
Beside the measured number, compound 3's estimate is 2.0-fold (0.30 log units) below it, and the stated range covers the measured number.
By their numbers in this assay, from the lowest: compound 1; then compound 3; then compound 2.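

In this assay, methyl in place of ethoxy on the carbonyl carbon gives a 5.0-fold higher number from compound 1 to compound 3 (0.70 log units; beyond the scatter), the first view of a single change at this position, and it shows that the group on this carbonyl carbon affects the read-out, with (ethoxycarbonyl)amino reading as the stronger inhibitor and acetamido as the weaker. The step combines two counted differences, since ethoxy brings 3 heavy atoms and 1 hydrogen-bond acceptor while methyl brings 1 heavy atom and no hydrogen-bond acceptor, so this one pair cannot separate the contribution of either. Nothing measured here gives a reason for the step.

On these data alone, whether the number keeps falling as the group on the carbonyl carbon grows remains open, and methoxy or a longer chain such as propoxy would test that trend from compound 1. As far as these compounds go, it is equally open how an amine such as dimethylamino would read at the same carbonyl carbon, which would keep a group larger than methyl there but replace the oxygen of ethoxy with nitrogen.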